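Adding a Fluoro Group to Compound 3

The compounds below may be only part of what the source reports. "The series", "measured", "known", "first", "only" and "open" are said of these compounds alone.

Measured compounds:
compound 1, `O=C(CSC(=S)N[C@H]1CCOC1=O)Nc1ccccc1F`: > 128000 nM
compound 2, `O=C(CSC(=S)N[C@H]1CCOC1=O)Nc1ccccc1`: > 128000 nM
compound 3, `O=C(CCl)Nc1ccc(C(=O)/C=C/c2ccc(F)cc2)cc1`: 15100 nM

In a functional assay on SMMC-7721 cells (Homo sapiens) for cytotoxicity, read by MTT assay, with a stated time of 72 h (a lower number here means a stronger inhibitor, a higher number a weaker inhibitor), compound 1 gives > 128000 nM, which is a limit of the assay and not a number. Compound 2 likewise gives > 128000 nM, again a limit. Compound 3 is the only one of the three that gives a number, 15100 nM. The change from compound 2 to compound 1 is fluoro in place of hydrogen on an aromatic carbon, and its step that the two limits leave unreadable from compound 2 to compound 1 cannot be read, since both ends rest on (the limit of > 128000 nM in this assay, at which 2 of the 3 values shown sit). How the core of compound 3 differs from the core of compound 2 is not broken down here.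

Compound 4, `O=C(CCl)Nc1ccc(C(=O)/C=C/c2ccc(F)c(F)c2)cc1`, has not been measured. It differs from compound 3 by fluoro in place of hydrogen on an aromatic carbon. This is the same kind of change as that from compound 2 to compound 1, but the surroundings differ: in compound 1 the fluoro sits ortho to a large group, whereas in compound 4 it sits ortho to a fluoro group and meta to a large group.

Among the compounds with values here, because the step that the two limits leave unreadable from compound 2 to compound 1 gives no readable size, the one measured example of this change offers no guidance, and a step within the usual scatter is expected from compound 3 to compound 4, a 1.3-fold lower number from compound 3 to compound 4 (0.10 log units; within the scatter). Compound 4 is therefore estimated at 12000 nM in this assay, between 5000 nM and 30000 nM.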

Compound 4, half-maximal inhibitory concentration: 5960 nM
Beside the measured number, compound 4's estimate is 2.0-fold (0.30 log units) above it, and the stated range covers the measured number.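

In this assay, fluoro in place of hydrogen on an aromatic carbon, ortho to a fluoro group and meta to a large group, gives a 2.5-fold lower number from compound 3 to compound 4 (0.40 log units; beyond the scatter), a modest step that lies beyond the usual scatter of repeated measurements. The same kind of change on the core of compound 2 cannot be read, since compound 2 and compound 1 both rest on a limit of the assay and not on a number: the limit of > 128000 nM in this assay, at which 2 of the 4 values shown sit. The series therefore holds one readable example of this change, on the core of compound 3, and it shows neither that the step carries over to the core of compound 2 nor that it fails to do so.

The compounds shown leave open whether another group at the same place on the ring of compound 4, such as chloro, methoxy or an amine, would give a step of similar size or direction. They also leave open how the step would look on a core whose parent compound gives a number in this assay and whether it would hold with a longer chain in place of the chloromethyl end of compound 3.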